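The compounds below may be only part of what the source reports. "The series", "measured", "known", "first", "only" and "open" are said of these compounds alone.

Four related compounds share one core. Compound 1 `CC1=CC[C@H]2[C@H](CC[C@]2(C)O)C(C)(C)[C@@H]1CC[C@H]1[C@]2(C)CC[C@H](OC(=O)c3ccc([N+](=O)[O-])cc3)C(C)(C)O[C@H]2CC[C@@]1(C)O` has been tested in a functional assay on MDA-MB-231 cells (Homo sapiens) for antiproliferative activity, read by MTT assay, with a stated time of 72 h (on this read-out lower numbers stand for stronger inhibition and higher numbers for weaker inhibition), and gives 8900 nM. Compound 2 `C=C(C)C(CC[C@@]1(C)C(CC[C@H]2[C@]3(C)CC[C@H](O)C(C)(C)O[C@H]3CC[C@@]2(C)O)=C(C)CC[C@H]1O)OO` in this assay reaches only a limit of the assay, > 50000 nM. Compound 3 `CC1=C(CC[C@H]2[C@]3(C)CC[C@H](O)C(C)(C)O[C@H]3CC[C@@]2(C)O)[C@](C)(C/C=C/C(C)(C)OO)[C@H](O)CC1` likewise stops at a limit in this assay, > 50000 nM. The step that the two limits leave unreadable from compound 2 to compound 3 therefore cannot be read. Compound 4 `CC1=C(CC[C@H]2[C@]3(C)CC[C@H](O)C(C)(C)O[C@H]3CC[C@@]2(C)O)[C@](C)(C/C=C/C(C)(C)O)[C@H](O)CC1` has not yet been measured; from compound 3 it differs by hydrogen in place of hydroxy on an oxygen on a saturated carbon. Within the data shown here, no measured step speaks to this particular change. Since compound 3 sits at the limit of > 50000 nM in this assay, at which 2 of the 3 values shown sit, only a limit is known as the starting point. Compound 4 is therefore expected to stay weak, with an estimated step that the limit leaves unreadable from compound 3 to compound 4. Compound 4 is estimated at 60000 nM, within a range from 20000 nM to 200000 nM.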

Compound 4, half-maximal inhibitory concentration: > 50000 nM
Compound 4 ended at the assay's limit (the forecaster's own chance of this, stated with the estimate: 70%); the middle value does not contradict the limit.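

Compound 2, compound 3 and compound 4 all stop at a limit in this assay, so no step among them can be read: the limit of > 50000 nM in this assay, at which 3 of the 4 values shown sit.

As far as these compounds go, whether the change from hydroxyoxy to hydroxy alters activity at all stays open.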